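Carbonyl substituent variation: amide to ester

The source may hold more compounds than are shown below. What is called first, only, known or untested is meant among the compounds shown, and "the series" means these compounds.

Measured so far:
compound 1 `CC1=C(C(N)=O)C(c2ccoc2)NC(=O)N1` gives 6% in an assay on membranes from HEK293 cells for displacement of a labelled ligand from adenosine receptor A2b (Homo sapiens), read by scintillation counting, with a stated time of 30 min, tested at 1 uM; on this read-out lower numbers stand for less inhibition and higher numbers for more inhibition at the one concentration tested (going by the name of the read-out)
compound 2 `CCN(CC)C(=O)C1=C(C)NC(=O)NC1c1ccoc1` gives 12% in this assay

Within the data shown here, compound 2 stands highest of the two numbers, but its only neighbour, compound 1, lies within the scatter: a number 6 percentage points higher from compound 1 to compound 2 (within the scatter). Compound 3 `CC1=C(C(=O)OC2CCCCC2)C(c2ccoc2)NC(=O)N1` carries cyclohexyloxy in place of diethylamino on a carbonyl carbon. Among the measured compounds shown here, the single measured step bears on the same carbonyl carbon and stayed within the scatter, and no step has yet replaced the carbonyl substituent with an ester. The step of no change at the digits printed from compound 2 to compound 3 (within the scatter) is therefore expected to stay within the scatter, in no clear direction. Compound 3 is estimated at 12%, within 0% to 30%.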

Compound 3, a percentage reported as inhibition, at one concentration (the size of the read-out at that concentration, not a potency): 4%
Compound 3: the middle estimate sits 8 percentage points above what was measured; the measured number falls inside the stated range.
By their numbers in this assay, from the lowest: compounds 3, 1 and 2 (each within the scatter of the next).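

Cyclohexyloxy, the only ester shown, gives a number 8 percentage points lower from compound 2 to compound 3 (within the scatter) when it replaces diethylamino, and a number 2 percentage points lower from compound 1 to compound 3 (within the scatter) when it replaces amino. In this assay, exchanging either amide for this ester on the carbonyl carbon therefore produces no step beyond the scatter, so all three carbonyl substituents remain indistinguishable. No supporting measurement bears on this result.

Still open, going by these compounds, is whether any substituent on this carbonyl carbon can move the read-out beyond the scatter. A carboxylic acid, a benzylamino group or a small ethoxy ester would test this.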